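Amide nitrogen swap: tert-butyl to pyridin-3-ylmethyl

The compounds below may be only part of what the source reports. "The series", "measured", "known", "first", "only" and "open" are said of these compounds alone.

Compound 3 `CCCn1c(SCc2cc([N+](=O)[O-])ccc2OC)nc2cc(NC(=O)NC(C)(C)C)cc(C(=O)NC(C)(C)C)c21` gives 490 nM in an assay on isolated protein for inhibition of Gonadotropin-releasing hormone receptor (Rattus norvegicus); a lower number here means a stronger inhibitor, a higher number a weaker inhibitor. Compound 2 `COc1ccc([N+](=O)[O-])cc1CSc1nc2cc(NC(=O)NC(C)(C)C)ccc2n1Cc1cccnc1` gives 150 nM in this assay, a lower number than compound 3 and a gap beyond the scatter, so compound 3 stands with the higher of the two numbers. Compound 1 `COc1ccccc1CSc1nc2cc(NC(=O)C3CC3)ccc2n1C(C)C` sits at the limit of > 10000 nM in this assay, at which 1 of the 3 values shown sits, a limit rather than a number, and is recorded in this assay as > 10000 nM.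

Compound 4 `CCCn1c(SCc2cc([N+](=O)[O-])ccc2OC)nc2cc(NC(=O)NC(C)(C)C)cc(C(=O)NCc3cccnc3)c21` differs from compound 3 in one place: (pyridin-3-yl)methyl in place of tert-butyl on an amide-type nitrogen. Among the measured compounds shown here, no measured pair shows this change, and the compounds with a (pyridin-3-yl)methyl group, such as compound 2, carry it elsewhere, so no direct reading of the step is available. The expected step from compound 3 to compound 4 in this assay is a 1.6-fold lower number from compound 3 to compound 4 (0.21 log units; within the scatter), a small lowering of the number that may well fall within the scatter. Compound 4 is therefore estimated at 300 nM in this assay, with an expected range from 80 nM to 1200 nM.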

Compound 4, half-maximal inhibitory concentration: 54 nM
For compound 4 the middle estimate is 5.6-fold (0.74 log units) above the measured one, outside the stated range (below it).
By their numbers in this assay, from the lowest: compound 4; then compound 2; then compound 3. At a limit, above all of these: compound 1.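

In this assay, among the compounds shown here, (pyridin-3-yl)methyl in place of tert-butyl on an amide-type nitrogen gives a 9.1-fold lower number from compound 3 to compound 4 (0.96 log units; beyond the scatter), the first step that can be read at this position. The position is therefore not tied to tert-butyl: a group with more heavy atoms, a six-membered aromatic ring and a hydrogen-bond acceptor gives the lower number here. No measurement among the compounds shown bears on the cause of this step.

A single pair cannot separate the contribution of the ring from that of its nitrogen, and a benzyl group on the same amide nitrogen would be the direct test. From the compounds shown here alone, how far the position extends also stays open, as does its response to a longer chain ending in an amine or a carboxylic acid.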